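Compound 3 and a single aromatic substituent swap

The compounds below may be only part of what the source reports. "The series", "measured", "known", "first", "only" and "open" are said of these compounds alone.

In a functional assay on LNCaP cells (Homo sapiens) for antiproliferative activity, read by propidium iodide staining, with a stated time of 96 h (a lower number here means a stronger inhibitor, a higher number a weaker inhibitor), compound 3 `CC(O)(CS(=O)(=O)c1ccc(S(F)(F)(F)(F)F)cc1)C(=O)Nc1ccc(S(F)(F)(F)(F)F)cc1` gives 29200 nM and stands within the scatter of compound 1 `CC(O)(COc1ccc(C#N)cc1C(F)(F)F)C(=O)Nc1cccc(S(F)(F)(F)(F)F)c1` at 16400 nM while compound 2 `CC(O)(CS(=O)(=O)c1ccc(S(F)(F)(F)(F)F)cc1)C(=O)Nc1ccc([N+](=O)[O-])cc1C(F)(F)F` at 12500 nM has a lower number, beyond the scatter. Compound 4 `CC(O)(CS(=O)(=O)c1ccc(OC(F)(F)F)cc1)C(=O)Nc1ccc(S(F)(F)(F)(F)F)cc1` departs from compound 3 by one change a group of 5 heavy atoms (1 carbon, 1 oxygen, 3 fluorine; no ring) in place of a group of 6 heavy atoms (5 fluorine, 1 sulfur; no ring), on an aromatic carbon on an aromatic carbon, para to a large group, where trifluoromethoxy enters. Among the compounds with values here, no measured pair shows this change, so in this assay only a small step is expected, with no firm direction. An estimated 1.3-fold lower number from compound 3 to compound 4 (0.12 log units; within the scatter) would stay within the scatter. For compound 4 the estimated value is 22000 nM (range 9000 nM to 50000 nM).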

Compound 4, half-maximal inhibitory concentration: 92800 nM
Compound 4: middle estimate off by 4.2-fold (0.63 log units), on the low side; measured number outside the range, above it.
By their numbers in this assay, from the lowest: compounds 2, 1 and 3 (each within the scatter of the next, the first and the last beyond it); then compound 4.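

In this assay, putting trifluoromethoxy in place of the group of 5 fluorine and 1 sulfur, on an aromatic carbon para to a large group, gives a 3.2-fold higher number from compound 3 to compound 4 (0.50 log units; beyond the scatter). This is the first sign among these compounds that the group at this place matters, and here the swap weakens activity. No measured property of these compounds accounts for the step.

On these data alone, it remains open how a chlorine, a methyl or an amine at this place would compare with these two groups. As far as these compounds go, whether the same swap would give a step of similar size in compound 2 is also open.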